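A few compounds are considered here, and "the series" means these few. Any claim that something is new, unique, unknown or untested is made for them only; others in the source may bear on it.

In a physicochemical assay for lipophilicity (on this read-out lower numbers stand for lower lipophilicity and higher numbers for higher lipophilicity), compound 1 `COc1ccc(-c2cnc3c(-c4ccncc4)cnn3c2)cc1` gives 4, compound 2 `O=c1cc(-c2cnc3c(-c4ccccc4)cnn3c2)ccn1CCCN1CCCCC1` gives 2.4 and compound 3 `CN1CCN(CCCn2ccc(-c3cnc4c(-c5ccccc5)cnn4c3)cc2=O)CC1` gives 2, the lowest of the three numbers. Compound 4 `CN1CCN(CCCn2ccc(-c3cnc4c(-c5ccsc5)cnn4c3)cc2=O)CC1` has not been measured yet. It differs from compound 3 in one group: thiophen-3-yl in place of phenyl on an aromatic carbon. In words, it carries thiophen-3-yl in place of phenyl on an aromatic carbon.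

Going by the values given here, no measured step makes this exchange, and compound 1 differs from the others in more than one place, so it offers no clean comparison. The nearest guide is a number 0.40 log units lower from compound 2 to compound 3 (beyond the scatter), a modest step. It comes from 4-methylpiperazin-1-yl replacing piperidin-1-yl on the chain, elsewhere in the molecule, so it suggests only the size a single exchange can have in this assay. One aromatic ring replacing another is expected to give no step beyond the scatter, and the estimated step is a number 0.20 log units lower from compound 3 to compound 4 (within the scatter). For compound 4 the expected value is 1.8, with an estimated range from 1.4 to 2.2.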

Compound 4, partition coefficient: 1.6
For compound 4 the middle estimate is 0.20 log units above the measured one; the range from low to high includes it.
By their numbers in this assay, from the lowest: compound 4; then compound 3; then compound 2; then compound 1.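

In this assay, the aromatic carbon of the five-membered aromatic ring with 2 nitrogen proves sensitive to a ring exchange: thiophen-3-yl in place of phenyl gives a number 0.40 log units lower from compound 3 to compound 4 (beyond the scatter), a change beyond the usual scatter. Going by these compounds alone, until now, the only single exchange that could be read lay on the chain, where a number 0.40 log units lower from compound 2 to compound 3 (beyond the scatter) appeared, so this is the first sign that the read-out also shifts with the ring on the shared core. No measurement shown gives a reason for this step.

The exchange alters ring size and brings in sulfur at once, so the compounds shown cannot separate the two. Furan-3-yl, with oxygen in place of sulfur, and thiophen-2-yl, with the same ring attached through a different carbon, would remain to be compared with thiophen-3-yl.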